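Swapping the aryl group on the carbonyl: compound 4

This account rests on a few compounds, and the source may have more. Where it says the series, first, only, none or still open, it means among the compounds named here.

Compound 1, `Cc1ccccc1C(=O)c1cc(Cl)ccc1Oc1ccnc(Nc2ccc(C#N)cc2)n1`, gives 28800 nM in an ADME assay on MT4 cells (Homo sapiens) for cytotoxicity, read by MTT assay, with a stated time of 5 days; on this read-out higher numbers stand for lower toxicity in this test and lower numbers for higher toxicity in this test. Compound 2, `Cc1ccc(C(=O)c2cc(Cl)ccc2Oc2cc(C)nc(Nc3ccc(C#N)cc3)n2)cc1`, gives 26600 nM in this assay. Compound 3, `Cc1cc(C)cc(C(=O)c2cc(Cl)ccc2Oc2cc(C)nc(Nc3ccc(C#N)cc3)n2)c1`, gives 37100 nM in this assay.

Compound 3 sits alongside the other two: its separation from compound 2 is a 1.4-fold higher number from compound 2 to compound 3 (0.14 log units; within the scatter), and its separation from compound 1 is also within the scatter, so no ranking among the three can be read from these numbers. The step to compound 4, `Cc1cc(Oc2ccc(Cl)cc2C(=O)c2ccccc2C)nc(Nc2ccc(C#N)cc2)n1`, makes the change (2-methylphenyl in place of 3,5-dimethylphenyl on a carbonyl carbon). Among the compounds with values here, only one measured step bears on this position, a 1.4-fold higher number from compound 2 to compound 3 (0.14 log units; within the scatter), which exchanged one methylphenyl for another on the same carbonyl carbon and stayed within the scatter. Compound 1 already carries a 2-methylphenyl on its carbonyl carbon, though with a different core from compound 4, and its number lies within the scatter of compound 3. On this basis the expected step of a 1.2-fold lower number from compound 3 to compound 4 (0.09 log units; within the scatter) is none beyond the scatter. Compound 4 is therefore estimated at 30000 nM in this assay, with a range from 15000 nM to 60000 nM.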

Compound 4, half-maximal cytotoxic concentration: 4240 nM
Compound 4: middle estimate off by 7.1-fold (0.85 log units), on the high side; measured number below the stated range.
By their numbers in this assay, from the lowest: compound 4; then compounds 2, 1 and 3 (each within the scatter of the next).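

In this assay the aryl group on the carbonyl carbon proves not to be interchangeable: 2-methylphenyl in place of 3,5-dimethylphenyl gives an 8.8-fold lower number from compound 3 to compound 4 (0.94 log units; beyond the scatter) and in place of 4-methylphenyl gives a 6.3-fold lower number from compound 2 to compound 4 (0.80 log units; beyond the scatter), both beyond the scatter, whereas the earlier exchange, a 1.4-fold higher number from compound 2 to compound 3 (0.14 log units; within the scatter), stayed within it. The 2-methylphenyl alone does not carry this drop, since compound 1 bears the same group and still has a high number. Methyl in place of hydrogen on an aromatic carbon of the core gives a 6.8-fold lower number from compound 1 to compound 4 (0.83 log units; beyond the scatter), so the low number appears only where the two features occur together.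

On these data alone, whether it would recur with an ethyl or a methoxy group in place of that methyl on the aryl ring stays open. Nothing among the data shown says why the number falls with these changes.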